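Phenyl ester to methyl ester: permeability of compound 4

This account rests on a few compounds, and the source may have more. Where it says the series, first, only, none or still open, it means among the compounds named here.

Compound 1 `Cc1c(F)ccc(C(=O)Nc2cc(C(=O)Oc3ccccc3)ccc2N2CCN(C)CC2)c1Cl`: 48 10^-6 cm/s in an ADME assay for permeability, using PAMPA, with a stated time of 4 h; on this read-out lower numbers stand for lower permeability and higher numbers for higher permeability
Compound 2 `Cc1c(F)c([N+](=O)[O-])cc(C(=O)Nc2cc(C(=O)Oc3ccccc3)ccc2N2CCN(C)CC2)c1Cl`: 56.3 10^-6 cm/s in this assay
Compound 3 `Cc1c(F)c(N)cc(C(=O)Nc2cc(C(=O)Oc3ccccc3)ccc2N2CCN(C)CC2)c1Cl`: 38 10^-6 cm/s in this assay

Compound 2 sits with the others within the scatter: a 1.2-fold higher number from compound 1 to compound 2 (0.07 log units; within the scatter) and a 1.5-fold lower number from compound 2 to compound 3 (0.17 log units; within the scatter), while a 1.3-fold lower number from compound 1 to compound 3 (0.10 log units; within the scatter). Compound 4 `COC(=O)c1ccc(N2CCN(C)CC2)c(NC(=O)c2cc([N+](=O)[O-])c(F)c(C)c2Cl)c1` differs from compound 2 by methyl in place of phenyl on an oxygen next to a carbonyl group. Within the data shown here, none of the measured steps touches that oxygen; all three concern the aromatic carbon and all stayed within the scatter, so they give no guide to this change. Among the measured compounds shown here, with no step bearing on it, no shift beyond the scatter is expected in this assay, but the uncertainty is wide. The step is expected to be a 1.4-fold lower number from compound 2 to compound 4 (0.15 log units; within the scatter). Compound 4 is therefore estimated at 40 10^-6 cm/s, with a range from 18 10^-6 cm/s to 75 10^-6 cm/s.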

Compound 4, apparent permeability: 74.8 10^-6 cm/s
Compound 4: the middle estimate sits 1.9-fold (0.27 log units) below what was measured, within the range that was stated.
By their numbers in this assay, from the lowest: compounds 3, 1, 2 and 4 (each within the scatter of the next).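

At the oxygen next to a carbonyl group, methyl in place of phenyl gives a 1.3-fold higher number from compound 2 to compound 4 (0.12 log units; within the scatter) in this assay. This is the first step shown at this place, and phenoxycarbonyl and methoxycarbonyl are not told apart on this read-out, even though a six-membered aromatic ring gives way to a single carbon. Nothing shown here accounts for the result. Still open, as far as these compounds go, is whether the same exchange reads alike with the amino group of compound 3 on the shared core. Also open, from the compounds shown here alone, is how ethyl on this oxygen, or a free carboxylic acid, would read.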